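From a 3-Fluorobenzyl Amide to a 4-Methoxyphenyl Amide

The source may report more compounds than this note shows. Statements on the series, on what has been measured and on what is new or still open speak of the compounds shown alone.

Three amides built on a shared core have been measured in an ADME assay on HepG2 2.2.15 cells (Homo sapiens) for cytotoxicity, read by MTT assay, with stated times of 48 h and 9 days; a lower number here means that less compound is tolerated, a higher number that more compound is tolerated. Compound 1 `COc1ccc2c(=O)c(/C=C/C(=O)Nc3cccc(Cl)c3)coc2c1` gives 1100000 nM, compound 2 `COc1ccc2c(=O)c(/C=C/C(=O)NCc3ccccc3)coc2c1` gives 376000 nM, and compound 3 `COc1ccc2c(=O)c(/C=C/C(=O)NCc3cccc(F)c3)coc2c1` gives 475000 nM. The data place compound 3 level with its unfluorinated benzyl counterpart, with a 1.3-fold higher number from compound 2 to compound 3 (0.10 log units; within the scatter). The gap to the 3-chlorophenyl amide is wider, with a 2.3-fold lower number from compound 1 to compound 3 (0.36 log units; beyond the scatter). The unsubstituted benzyl amide shows a similar gap, with a 2.9-fold lower number from compound 1 to compound 2 (0.47 log units; beyond the scatter).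

Compound 4 `COc1ccc(NC(=O)/C=C/c2coc3cc(OC)ccc3c2=O)cc1` has not yet been measured. It carries 4-methoxyphenyl in place of 3-fluorobenzyl on an amide-type nitrogen. This change runs broadly opposite to the two modest steps away from compound 1, restoring a phenyl group in place of a benzyl group. Among the compounds with values here, that evidence is thin, as it rests on compound 1 at 1100000 nM alone, and no measured compound carries the 4-methoxyphenyl group. Only part of that gap is therefore expected to return, in the upward direction, and the rise may stay inside the scatter. The expected change is a 1.7-fold higher number from compound 3 to compound 4 (0.23 log units; within the scatter). The estimated value for compound 4 is 800000 nM, with an expected range from 300000 nM to 1800000 nM.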

Compound 4, half-maximal cytotoxic concentration: 718000 nM
For compound 4 the middle estimate is 1.1-fold (0.05 log units) above the measured one; the range from low to high includes it.
By their numbers in this assay, from the lowest: compounds 2, 3, 4 and 1 (each within the scatter of the next, the first and the last beyond it).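

At this place on the amide-type nitrogen, 4-methoxyphenyl stands apart from none of the three other groups in this assay, whether set against 3-fluorobenzyl (a 1.5-fold higher number from compound 3 to compound 4 (0.18 log units; within the scatter)), against benzyl (a 1.9-fold higher number from compound 2 to compound 4 (0.28 log units; within the scatter)) or against 3-chlorophenyl (a 1.5-fold lower number from compound 1 to compound 4 (0.19 log units; within the scatter)). The first three compounds had shown one phenyl amide set apart from two benzyl amides, but compound 4, also a phenyl amide, lies within the scatter of both sides, so that division does not hold as a clean rule across the four compounds, with compound 4 the one that goes against it. No data at hand explain this result.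

Going by these compounds, what stays open is where an unsubstituted phenyl would fall, and so whether the 4-methoxy group or the 3-chloro group matters at all on a phenyl amide. Equally open, on these data alone, is whether a longer chain such as 2-phenylethyl, or an amine or a carboxylic acid on the aromatic ring, would move the number clear of the scatter.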